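This account rests on a few compounds, and the source may have more. Where it says the series, first, only, none or still open, it means among the compounds named here.

Compound 1 `O=C(c1ccccc1)c1ccc(NS(=O)(=O)c2ccc(Cl)cc2Cl)cc1` is a sulfonamide. Among the compounds with values here, in an assay on CHO cells for binding affinity to integrin alpha-1 (Homo sapiens), read by WST assay, with a stated time of 2 h, tested at 50 uM (on this read-out lower numbers stand for less inhibition and higher numbers for more inhibition at the one concentration tested (going by the name of the read-out)), compound 1 gives 82%, the higher of the two numbers measured so far. Compound 2 `O=C(c1ccccc1)c1cccc(NS(=O)(=O)c2ccc(Cl)cc2Cl)c1` gives 69% in this assay, and the gap between these two values lies beyond the usual scatter. Compound 3 `CN(c1ccc(C(=O)c2ccccc2)cc1)S(=O)(=O)c1ccc(Cl)cc1Cl` differs from compound 1 in one place: methyl in place of hydrogen on a sulfonamide nitrogen. Within the data shown here, no measured pair shows what this change does, so any expectation rests on compound 1 alone. The step of a number 17 percentage points lower from compound 1 to compound 3 (beyond the scatter) is expected to be a moderate fall in inhibition. Compound 3 is therefore estimated at 65%, with a range from 40% to 85%.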

Compound 3, a percentage reported as inhibition, at one concentration (the size of the read-out at that concentration, not a potency): 0%
Beside the measured number, compound 3's estimate is 65 percentage points above it, outside the stated range (below it).
By their numbers in this assay, from the lowest: compound 3; then compound 2; then compound 1.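

In this assay, methyl in place of hydrogen on the sulfonamide nitrogen gives a large fall, a number 82 percentage points lower from compound 1 to compound 3 (beyond the scatter), so a single added carbon at this position is enough to remove all inhibition seen at the one concentration tested. Compound 1 and compound 2 both keep this hydrogen, so neither could show how much depends on it. Nothing available explains the loss. From the compounds shown here alone, whether a longer chain such as ethyl, or an acetyl group, on this nitrogen behaves the same way stays open, as does the effect of methyl on compound 2.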